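The source may hold more compounds than are shown below. What is called first, only, known or untested is meant among the compounds shown, and "the series" means these compounds.

Measured so far in a functional assay on HepG2 cells (Homo sapiens) for antiproliferative activity, read by CCK-8 assay, with a stated time of 72 h, tested at 2 uM; on this read-out higher numbers stand for a stronger effect at the one concentration tested and lower numbers for a weaker effect:
compound 1 `CN1CCN(c2nc(Cl)nc3c2ncn3Cc2ccc(C(=O)Nc3ccccc3N)cc2)CC1`: 60.4%
compound 2 `CC(C)n1cnc2c(Nc3cccc(Cl)c3)nc(NCOCc3ccc(C(=O)Nc4ccccc4N)cc3)nc21`: 1.48%
compound 3 `Nc1ccccc1NC(=O)/C=C/c1ccc(Cn2cnc3c(Nc4cccc(Cl)c4)nc(Cl)nc32)cc1`: 35.8%

Compound 3 stands second highest of the three numbers in this assay. Compound 1 lies above it by a gap beyond the scatter, and compound 2 lies below it, again by a gap beyond the scatter. Going by the values given here, no two of the measured compounds differ in one place only, so no single measured step is available to lean on.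

Compound 4 `Nc1ccccc1NC(=O)/C=C/c1ccc(Cn2cnc3c(NC4CCCCC4)nc(Cl)nc32)cc1` differs from compound 3 as follows: cyclohexyl in place of 3-chlorophenyl on a nitrogen on an aromatic ring. Among the compounds with values here, the measured set holds no example of cyclohexyl in place of 3-chlorophenyl on a nitrogen on an aromatic ring, so the expectation rests on compound 3 alone, which gives 35.8% in this assay. A step of modest size is expected, with the direction uncertain and a slight lean downward; the estimated step is a number 5.8 percentage points lower from compound 3 to compound 4 (within the scatter). Compound 4 is expected to give 30% in this assay, with a range from 10% to 55%.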

Compound 4, a percentage reported as inhibition, at one concentration (the size of the read-out at that concentration, not a potency): 3.83%
Compound 4: the middle estimate sits 26.2 percentage points above what was measured; measured number below the stated range.
By their numbers in this assay, from the lowest: compounds 2 and 4 (each within the scatter of the next); then compound 3; then compound 1.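

In this assay, going by these compounds alone, the first measured step, a number 32 percentage points lower from compound 3 to compound 4 (beyond the scatter), comes from placing cyclohexyl in place of 3-chlorophenyl on a nitrogen on an aromatic ring, so the group at this position is not interchangeable with respect to the read-out. The change removes both the chlorine and the aromatic character of the ring, and this single step cannot separate those two differences. Nothing available here bears on the origin of the step.

As far as these compounds go, whether the step follows the chlorine or the aromatic ring stays open, and an unsubstituted phenyl or a 3-methoxyphenyl on the same nitrogen would begin to separate the two. Also open, from the compounds shown here alone, is whether (3-chlorophenyl)amino to cyclohexylamino gives a step of this size when the rest of the molecule matches compound 1 or compound 2.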